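A few compounds are considered here, and "the series" means these few. Any claim that something is new, unique, unknown or untested is made for them only; others in the source may bear on it.

Measured in a functional assay on MCF7 cells (Homo sapiens) for cytotoxicity, read by MTT assay, with a stated time of 72 h; a higher number here means a weaker inhibitor, a lower number a stronger inhibitor:
- compound 1 `N/C(=N\NC(=S)N1CCCCCC1)c1ccccn1`: 2600 nM
- compound 3 `N/C(=N\NC(=S)N1CCCC1)c1ccc(F)cn1`: 900 nM
- compound 2 `Cc1ccnc(/C(N)=N/NC(=S)N2CCOCC2)c1` gives only a limit of the assay, > 100000 nM.

Compound 3 holds the lowest of the two numbers in this assay, and the nearest number, that of compound 1, lies beyond the usual scatter above it. The third value, that of compound 2, sits at the limit of > 100000 nM in this assay, at which 1 of the 3 values shown sits, and gives no number to compare.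

Compound 4 `N/C(=N\NC(=S)N1CCOCC1)c1ccc(F)cn1` is the next step from compound 3: morpholin-4-yl in place of pyrrolidin-1-yl on a thiocarbonyl carbon. Within the data shown here, no pair of measured compounds differs in this place alone, so the size of this step is not known directly. Compound 2 also carries a morpholin-4-yl on the thiocarbonyl carbon, but it differs from compound 4 in another place as well, so its limit is only a weak pointer.

In this assay a step towards a higher number is expected, clearly beyond the scatter. Compound 4 is estimated at 6000 nM, within a range from 1500 nM to 40000 nM. The step this estimate means is a 6.7-fold higher number from compound 3 to compound 4 (0.82 log units; beyond the scatter).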

Compound 4, half-maximal inhibitory concentration: 22100 nM
The estimate for compound 4 lay 3.7-fold (0.57 log units) below the measured number; the measured number falls inside the stated range.
By their numbers in this assay, from the lowest: compound 3; then compound 1; then compound 4. At a limit, above all of these: compound 2.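

In this assay, among these compounds, this is the first direct reading of the place on the thiocarbonyl carbon: morpholin-4-yl in place of pyrrolidin-1-yl gives a 25-fold higher number from compound 3 to compound 4 (1.39 log units; beyond the scatter), so with the rest of the molecule unchanged, the group at this place has a large bearing on the number. The change replaces a five-membered ring with a six-membered ring that also holds an oxygen and a hydrogen-bond acceptor, and since these differences arrive together, this single step cannot divide its size among them. Compound 2, which also carries morpholin-4-yl on the thiocarbonyl carbon, gives only a limit of the assay and differs from compound 4 in another place as well, so it adds no second measure of this change: the limit of > 100000 nM in this assay, at which 1 of the 4 values shown sits.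

The compounds shown leave open whether ring size or the ring oxygen accounts for the step, a question that piperidin-1-yl on the same carbon, a six-membered ring without the oxygen, would address directly. They also leave open whether the step keeps its size when the fluoro group on the shared core gives way to a hydrogen or a methyl.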